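The compounds below may be only part of what the source reports. "The series", "measured", "known", "first", "only" and "open" are said of these compounds alone.

In a functional assay on A549 cells (Homo sapiens) for cytotoxicity, read by MTT assay, with a stated time of 72 h (on this read-out higher numbers stand for weaker inhibition and lower numbers for stronger inhibition), compound 3 `CN(C)CCn1cnnc1-c1cc(Oc2ccc(NC(=O)N/N=C/c3ccc(Cl)cc3)cc2F)ccn1` gives 780 nM, the lowest of the two numbers shown, with compound 1 `CN(C)CCn1cnnc1-c1cc(Oc2ccc(NC(=O)N/N=C/c3cccc(Br)c3)cc2F)ccn1` nearest at 970 nM. Compound 2 `CN(C)CCn1cnnc1-c1cc(Oc2ccc(NC(=O)N/N=C/c3cccc(O)c3)cc2F)ccn1` reaches only the limit of this assay at > 100000 nM. Compound 4 `CN(C)CCn1cnnc1-c1cc(Oc2ccc(NC(=O)N/N=C/c3cccc(Cl)c3Cl)cc2F)ccn1` awaits measurement; it differs from compound 3 by 2,3-dichlorophenyl in place of 4-chlorophenyl on a carbon with a double bond to nitrogen. Among the compounds with values here, two measured steps bear on this change: the shift of one halogen a 1.2-fold lower number from compound 1 to compound 3 (0.09 log units; within the scatter), and the exchange of a halogen for a hydroxy group an at least 100-fold higher number from compound 1 to compound 2 (2.01 log units; beyond the scatter). The present change keeps halogens on the ring, so the small halogen step is the closer guide, and the expected step is a 1.1-fold lower number from compound 3 to compound 4 (0.05 log units; within the scatter), not beyond the scatter. Compound 4 is therefore expected to give 700 nM in this assay, between 300 nM and 2500 nM.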

Compound 4, half-maximal inhibitory concentration: 1090 nM
Beside the measured number, compound 4's estimate is 1.6-fold (0.19 log units) below it; the measured number falls inside the stated range.
By their numbers in this assay, from the lowest: compounds 3, 1 and 4 (each within the scatter of the next). At a limit, above all of these: compound 2.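

With 2,3-dichlorophenyl at this position, a second chlorine on the ring stays within the scatter of both single-halogen compounds, as shown by a 1.4-fold higher number from compound 3 to compound 4 (0.15 log units; within the scatter) and by a 1.1-fold higher number from compound 1 to compound 4 (0.05 log units; within the scatter). So in this assay, this position accepts two chlorines as well as one halogen, at either ring location shown. The gap to the 3-hydroxyphenyl compound, an at least 91-fold lower number from compound 2 to compound 4 (1.96 log units; beyond the scatter), remains large, but it starts from a limit: the limit of > 100000 nM in this assay, at which 1 of the 4 values shown sits.

The compounds shown leave open how a methoxy group, an amine or a carboxylic acid on this ring would read. They also leave open whether an unsubstituted phenyl would keep these numbers.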